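The source may report more compounds than this note shows. Statements on the series, on what has been measured and on what is new or still open speak of the compounds shown alone.

Working notes on the shared core of compound 1, `CCC1(Cc2ccccc2)OS(=O)(=O)C=C1OCC(=O)OC`, and its near relatives. In an ADME assay on HEL cells (Homo sapiens) for cytotoxicity, with a stated time of 3 days (a lower number here means that less compound is tolerated, a higher number that more compound is tolerated), compound 1 reaches only a limit, > 400000 nM, so no number is known for it. Compound 2, `CCC1(Cc2ccccc2)OS(=O)(=O)C=C1OS(=O)(=O)c1ccc(C)cc1`, gives 400000 nM in this assay. Compound 3, `CC(C)CC1(Cc2ccccc2)OS(=O)(=O)C=C1OCc1ccccc1`, also ends at a limit in this assay, >= 80000 nM, and nothing more is known for it. Compound 1 therefore stands at the upper edge of the series: its value is the limit of > 400000 nM in this assay, at which 1 of the 3 values shown sits, a second compound sits at the limit of >= 80000 nM in this assay, at which 1 of the 3 values shown sits, and only compound 2 gives a plain number. For the measured compounds named here, no pair of measured compounds differs in a single place, so the measured set gives no step from which the size of a structural change can be read.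

Compound 4, `CCC1(Cc2ccccc2)OS(=O)(=O)C=C1OCCc1ccccc1`, differs from compound 1 in one place: benzyl in place of methoxycarbonyl on a saturated chain carbon bound to an oxygen on an unsaturated carbon.

Because compound 1 stands at the limit of > 400000 nM in this assay, at which 1 of the 3 values shown sits, and every value seen is at or close to the top of the range, the step from compound 1 to compound 4 in this assay is expected to be none beyond the scatter or a modest move downward, an at least 1.3-fold lower number from compound 1 to compound 4 (0.12 log units; that floor lies within the scatter). Compound 4 is accordingly expected to give about 300000 nM in this assay, within 100000 nM to 400000 nM, with a fair chance that only a limit is returned.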

Compound 4, minimum cytotoxic concentration: >= 20000 nM
Compound 4 was reported as a limit (the forecaster's own chance of this, stated with the estimate: 50%); the middle value lies beyond the limit too.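

Compound 1 and compound 4 both end at limits in this assay, and the size of the step between them cannot be read. The compounds shown leave open whether benzyl in place of methoxycarbonyl on a saturated chain carbon bound to an oxygen on an unsaturated carbon changes the minimum cytotoxic concentration at all.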